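This account rests on a few compounds, and the source may have more. Where it says the series, first, only, none or still open, it means among the compounds named here.

Measured compounds in a functional assay on PC-3 cells (Homo sapiens) for cytotoxicity, read by MTT assay, with a stated time of 72 h; a lower number here means a stronger inhibitor of growth, a higher number a weaker inhibitor of growth:

- compound 1, `N#CSCN1C(=O)c2ccccc2C1=O`: > 100000 nM, which is a limit of the assay and not a number.
- compound 2, `N#C[Se]CN1C(=O)c2ccccc2C1=O`: 32100 nM.
- compound 3, `N#CSCc1ccc(-n2cccc2)cc1`: 60300 nM.

Compound 1 and compound 2 share a core and differ by a group of 3 heavy atoms (1 carbon, 1 nitrogen, 1 selenium; no ring) in place of a group of 3 heavy atoms (1 carbon, 1 nitrogen, 1 sulfur; no ring), on a saturated chain carbon bound to an amide-type nitrogen in a ring. That change gives an at least 3.1-fold lower number from compound 1 to compound 2 (0.49 log units; beyond the scatter); the size of this step is bounded only by the limit of > 100000 nM in this assay, at which 1 of the 3 values shown sits, so it may be larger than stated. Compound 3 carries a different core; the difference between the core of compound 3 and the core of compound 1 is not broken down here. Compound 3 and compound 2 stand within the usual scatter of each other in this assay , so no order between them is claimed.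

Compound 4, `N#C[Se]Cc1ccc(-n2cccc2)cc1`, is not yet measured. It differs from compound 3 by a group of 3 heavy atoms (1 carbon, 1 nitrogen, 1 selenium; no ring) in place of a group of 3 heavy atoms (1 carbon, 1 nitrogen, 1 sulfur; no ring), on a saturated chain carbon bound to an aromatic carbon. Within the data shown here, this is the same kind of change as the one from compound 1 to compound 2, but the place differs: in the measured pair the group sits on a saturated chain carbon bound to an amide-type nitrogen in a ring, whereas in compound 4 it sits on a saturated chain carbon bound to an aromatic carbon. On the strength of the measured step from compound 1 to compound 2, an at least 3.1-fold lower number from compound 1 to compound 2 (0.49 log units; beyond the scatter), a step of similar direction and modest size is expected, written as a 3.0-fold lower number from compound 3 to compound 4 (0.48 log units; beyond the scatter). Among the measured compounds shown here, only one measured example of the change exists, on a different core, so the expectation is held loosely and a wide range is given. Compound 4 is accordingly estimated at 20000 nM in this assay , with a range from 7000 nM to 60000 nM.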

Compound 4, concentration for total growth inhibition: > 100000 nM
Compound 4: only a limit was reported; the forecaster's own chance of this, stated with the estimate: 5%; at least 5.0-fold (0.69 log units) between middle value and limit.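

In this assay compound 4 gives > 100000 nM, which is a limit of the assay and not a number. On the core of compound 3, replacing cyanosulfanyl with the matching group that carries selenium in place of sulfur gives an at least 1.6-fold higher number from compound 3 to compound 4 (0.21 log units; that floor lies within the scatter), so the lowering seen on the core of compound 1 does not carry over to this second core, and the two steps differ: the same change on two cores in this assay, an at least 3.1-fold lower number (0.49 log units; beyond the scatter) from compound 1 to compound 2 and an at least 1.6-fold higher number (0.21 log units; that floor lies within the scatter) from compound 3 to compound 4, at least 5.1-fold (0.71 log units) apart, beyond the scatter of two such steps. This does not fix the true size of either step, nor does it show that the change on the core of compound 3 clearly raises the number, since both steps are bounded only by the assay limit: the limit of > 100000 nM in this assay, at which 2 of the 4 values shown sit.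

With one matched pair on each of two cores, the compounds shown leave open which of the two outcomes is more typical of this exchange in the series, and what in the cores sets them apart. Also open, as far as these compounds go, is whether the exchange would behave the same way with a longer chain in place of the single saturated chain carbon, or with an amine or a carboxylic acid added to the core of compound 3.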